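From Acetamide to Propanamide on a Second Core

This account rests on a few compounds, and the source may have more. Where it says the series, first, only, none or still open, it means among the compounds named here.

Compound 1, `COc1ccccc1CCCNC(C)=O`: 1430 nM
Compound 2, `CCC(=O)NCCCc1ccccc1OC`: 374 nM
Compound 3, `CC(=O)NCCCc1cccc(F)c1`: 1920 nM

Of the compounds shown here, three have been measured in an assay for binding affinity to melatonin receptor (Gallus gallus); a lower number here means a stronger inhibitor, a higher number a weaker inhibitor. Compound 1 and compound 2 share one core and differ by methyl in place of hydrogen on a saturated chain carbon bound to a carbonyl carbon; that change gave a 3.8-fold lower number from compound 1 to compound 2 (0.58 log units; beyond the scatter). Compound 3 carries a different core; how its core differs from that of compound 1 is not broken down here, and in this assay compound 3 sits close to compound 1, the gap between the two lying within the usual scatter.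

Compound 4, `CCC(=O)NCCCc1cccc(F)c1`, has not yet been measured. It differs from compound 3 by methyl in place of hydrogen on a saturated chain carbon bound to a carbonyl carbon, the same change that separates compound 1 from compound 2. A step of similar size is expected here, a 3.8-fold lower number from compound 3 to compound 4 (0.58 log units; beyond the scatter), because the same change gave a 3.8-fold lower number from compound 1 to compound 2 (0.58 log units; beyond the scatter) on the first core. Compound 4 is therefore estimated at 500 nM, with a likely range from 250 nM to 1200 nM.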

Compound 4, inhibition constant: 740 nM
For compound 4 the middle estimate is 1.5-fold (0.17 log units) below the measured one; the measured number falls inside the stated range.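

In this assay, going from acetamido to propanoylamino on the second core gives a 2.6-fold lower number from compound 3 to compound 4 (0.41 log units; beyond the scatter), so the change lowers the number here as it did on the first core. Set side by side, the two steps do not differ beyond what repeat measurements would produce: the same change on two cores in this assay, a 3.8-fold lower number (0.58 log units; beyond the scatter) from compound 1 to compound 2 and a 2.6-fold lower number (0.41 log units; beyond the scatter) from compound 3 to compound 4, 1.5-fold (0.17 log units) apart, within the scatter of two such steps. This shows the change carrying over between these two cores at a similar size, but two pairs cannot show that it would hold on any other core, and they do not explain why the number falls.

The compounds shown leave open whether a longer chain, such as butanoyl in place of propanoyl, would lower the number again. From the compounds shown here alone, what a ring such as cyclopropyl would do at the same place also remains open.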